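The source may report more compounds than this note shows. Statements on the series, on what has been measured and on what is new or still open speak of the compounds shown alone.

Measured in an assay on cell membranes for displacement of a labelled ligand from Sigma non-opioid intracellular receptor 1 (Cavia porcellus), read by scintillation counting, with a stated time of 150 min; a higher number here means a weaker inhibitor, a lower number a stronger inhibitor:
compound 1 `COc1ccc(/C(C)=C/CN(C)Cc2ccccc2)cc1` gives 5.25 nM
compound 2 `COc1ccc(/C(C)=C/CN(C)C)cc1` gives 806 nM
compound 3 `C/C(=C\CN(C)C)c1ccc(-c2ccccc2)cc1` gives 1.4 nM

Compound 1 stands second highest of the three numbers: compound 3 sits closer to it, while compound 2 lies far above it. Compound 4 `C/C(=C\CN(C)Cc1ccccc1)c1ccccc1` differs from compound 1 by hydrogen in place of methoxy on an aromatic carbon, the place being an aromatic carbon of a six-membered aromatic ring of carbon only, para to a large group. Going by the values given here, no measured step removes a methoxy for hydrogen; the two measured steps concern other changes, a 150-fold higher number from compound 1 to compound 2 (2.19 log units; beyond the scatter) and a 580-fold lower number from compound 2 to compound 3 (2.76 log units; beyond the scatter). The benzyl group that the second of these shows to matter remains in compound 4, so compound 4 is expected to stay near compound 1, with an estimated step of a 1.5-fold higher number from compound 1 to compound 4 (0.18 log units; within the scatter) in this assay. Compound 4 is therefore estimated at 8 nM, within a range from 2 nM to 30 nM.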

Compound 4, inhibition constant: 92 nM
Compound 4: the middle estimate sits 12-fold (1.06 log units) below what was measured; measured number outside the range, above it.
By their numbers in this assay, from the lowest: compound 3; then compound 1; then compound 4; then compound 2.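

In this assay, replacing the methoxy with hydrogen while the benzyl group stays on the nitrogen gives an 18-fold higher number from compound 1 to compound 4 (1.24 log units; beyond the scatter). This place, para to a large group, therefore counts even with the benzyl group present, whereas the earlier step at this place concerned only a compound without it. No evidence given here accounts for the size of this step.

The compounds shown leave open how a hydroxyl, a chlorine or a phenyl at this place would read with the benzyl group kept on the nitrogen.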